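The source may report more compounds than this note shows. Statements on the series, on what has been measured and on what is new or still open speak of the compounds shown alone.

Measured compounds:
compound 1 `CC(C)(C)c1cc(NC(=O)[C@@H]2CCCCN2C2CC2)no1`, 38 ug/mL
compound 2 `CC(C)CN1CCCC[C@H]1C(=O)Nc1cc(C(C)(C)C)on1`, 32 ug/mL
compound 3 `CC(C)(C)c1cc(NC(=O)[C@@H]2CCCCN2C(=O)c2ccccc2)no1`, 0.9 ug/mL

In a physicochemical assay for solubility, read by HPLC, at pH 6.8 (a lower number here means a less soluble compound, a higher number a more soluble compound), compound 3 stands lowest of the three, set apart by a 42-fold lower number from compound 1 to compound 3 (1.63 log units; beyond the scatter) and a 36-fold lower number from compound 2 to compound 3 (1.55 log units; beyond the scatter). Compound 4 `CC(C)(C)c1cc(NC(=O)[C@@H]2CCCCN2C(=O)C2CCOCC2)no1` keeps the acyl group on the ring nitrogen and differs from compound 3 by oxan-4-yl in place of phenyl on a carbonyl carbon. Going by the values given here, no measured step touches the group on the carbonyl carbon: the two large steps concern exchange of an alkyl for an acyl group on the ring nitrogen, which compound 4 retains, while a 1.2-fold lower number from compound 1 to compound 2 (0.07 log units; within the scatter) lies within the scatter. The change is therefore untested here; a modest rise in this assay is expected, possibly not beyond the scatter. Compound 4 is expected at 3 ug/mL, range 1 ug/mL to 10 ug/mL. This estimate means an expected step of a 3.3-fold higher number from compound 3 to compound 4 (0.52 log units; beyond the scatter).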

Compound 4, solubility: 48 ug/mL
Beside the measured number, compound 4's estimate is 16-fold (1.20 log units) below it, and the stated range ends below it.
By their numbers in this assay, from the lowest: compound 3; then compounds 2, 1 and 4 (each within the scatter of the next).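

In this assay, the step at this position is large: a 53-fold higher number from compound 3 to compound 4 (1.73 log units; beyond the scatter) comes with oxan-4-yl in place of phenyl on a carbonyl carbon, so an acyl group on the ring nitrogen does not by itself go with the low number of compound 3. With (oxan-4-yl)carbonyl on the ring nitrogen, a 1.5-fold higher number from compound 2 to compound 4 (0.18 log units; within the scatter) and a 1.3-fold higher number from compound 1 to compound 4 (0.10 log units; within the scatter) both leave compound 4 level with the two alkyl-bearing compounds. No measurement here bears on the reason for the large step.

Open, going by these compounds, is whether the ring oxygen or the loss of the aromatic ring accounts for the step, which cyclohexyl on the same carbonyl carbon would separate. Also open, on these data alone, is how an amine or a carboxylic acid would read at this position.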